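Shortening the Acid Side Chain on a Diketopiperazine Core

The compounds below may be only part of what the source reports. "The series", "measured", "known", "first", "only" and "open" are said of these compounds alone.

Among the compounds with values here, compound 1 `CC(C)C[C@@H]1NC(=O)[C@H](CCC(=O)O)NC1=O` gives 97.8% in a functional assay, tested at 2.5 mM (a lower number here means less inhibition, a higher number more inhibition at the concentration tested (going by the name of the read-out)), the higher of the two numbers measured so far. Compound 2 `CC(C)C[C@@H]1NC(=O)[C@H](CC(N)=O)NC1=O` gives 96% in this assay, and the step of a number 1.8 percentage points lower from compound 1 to compound 2 (within the scatter) shows that the number in this assay stays level across this change at the side chain. Compound 3 `CC(C)C[C@@H]1NC(=O)[C@H](CC(=O)O)NC1=O` differs from compound 1 by carboxy in place of carboxymethyl on a saturated chain carbon bound to a saturated ring carbon. Within the data shown here, only the step from compound 1 to compound 2 bears on this, and it lay within the scatter, so no step beyond the scatter is expected in this assay. Compound 3 is therefore estimated at 93%, within 78% to 100%, a step of a number 4.8 percentage points lower from compound 1 to compound 3 (within the scatter).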

Compound 3, a percentage reported as inhibition, at one concentration (the size of the read-out at that concentration, not a potency): 95%
The estimate for compound 3 lay 2 percentage points below the measured number; measured number inside the range.
By their numbers in this assay, from the lowest: compounds 3, 2 and 1 (each within the scatter of the next).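

Cutting the chain from 2-carboxyethyl to carboxymethyl gives a number 2.8 percentage points lower from compound 1 to compound 3 (within the scatter) in this assay and so leaves the number level, which shows that this shorter acid side chain holds up as well as the longer one. Hydroxy in place of amino on a carbonyl carbon gives a number 1 percentage points lower from compound 2 to compound 3 (within the scatter) at the same chain length, so this change also shows no readable step. Nothing at hand accounts for these level numbers. Going by these compounds, whether an amine, an ester or a longer chain at this place would keep the number level remains open. A read-out at one concentration also leaves open whether compound 1, compound 2 and compound 3 would differ at lower concentrations.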